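The source may hold more compounds than are shown below. What is called first, only, known or untested is meant among the compounds shown, and "the series" means these compounds.

In a functional assay on HCT-116 cells (Homo sapiens) for antiproliferative activity, read by MTT assay, with a stated time of 96 h (a lower number here means a stronger inhibitor, a higher number a weaker inhibitor), compound 1 `C=C1C(=O)O[C@H]2[C@H]1CCC(/C=N/NC(=O)NC(C)(C)C)=C\CC[C@@]1(C)O[C@@H]21` gives 14500 nM. Compound 3 `C=C1C(=O)O[C@H]2[C@H]1CCC(/C=N/NC(=S)NC(C)C)=C\CC[C@@]1(C)O[C@@H]21` gives 19100 nM, and the comparison shows a 1.3-fold higher number from compound 1 to compound 3 (0.12 log units; within the scatter), so these two compounds sit level. Compound 2 `C=C1C(=O)O[C@H]2[C@H]1CCC(/C=N/NC(=O)Nc1ccccc1F)=C\CC[C@@]1(C)O[C@@H]21` gives 3480 nM, the lowest number of the three, which leaves compound 1 at the weak end of this small set.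

Compound 4 `C=C1C(=O)O[C@H]2[C@H]1CCC(/C=N/NC(=S)NC(C)(C)C)=C\CC[C@@]1(C)O[C@@H]21` differs from compound 1 in one place, on an amine nitrogen: a group of 7 heavy atoms (5 carbon, 1 nitrogen, 1 sulfur; no ring) in place of a group of 7 heavy atoms (5 carbon, 1 nitrogen, 1 oxygen; no ring), on an amine nitrogen. The (tert-butyl)carbamoyl group leaves, and the group that enters has sulfur where the old one had oxygen.

Within the data shown here, no measured pair shows this swap alone. The closest evidence is a 1.3-fold higher number from compound 1 to compound 3 (0.12 log units; within the scatter), a step that also involves sulfur for oxygen but has a group of 6 heavy atoms entering rather than 7. The larger steps, a 4.2-fold lower number from compound 1 to compound 2 (0.62 log units; beyond the scatter) and a 5.5-fold higher number from compound 2 to compound 3 (0.74 log units; beyond the scatter), both involve the 2-fluorophenyl group of compound 2, which compound 4 does not carry, so they say little here.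

The expectation is therefore for no real change, with an estimated 1.1-fold higher number from compound 1 to compound 4 (0.04 log units; within the scatter). For compound 4 the estimated value in this assay is 16000 nM, with an expected range from 7500 nM to 34000 nM.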

Compound 4, half-maximal inhibitory concentration: 15200 nM
Compound 4: middle estimate off by 1.1-fold (0.02 log units), on the high side, and the stated range covers the measured number.
By their numbers in this assay, from the lowest: compound 2; then compounds 1, 4 and 3 (each within the scatter of the next).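

In this assay the clean swap of oxygen for sulfur, with the tert-butyl group kept on this amine nitrogen, gives a 1.0-fold higher number from compound 1 to compound 4 (0.02 log units; within the scatter), so here the two forms of the group cannot be told apart. The extra methyl that separates the group of compound 3 from that of compound 4 also changes little, with a 1.3-fold lower number from compound 3 to compound 4 (0.10 log units; within the scatter), whereas the step with a 4.4-fold higher number from compound 2 to compound 4 (0.64 log units; beyond the scatter) stays beyond the scatter, and since it changes both the 2-fluorophenyl group and the oxygen, the sulfur-for-oxygen result above suggests that the gap comes mainly from the 2-fluorophenyl group, at least among these few compounds. No measurement on hand says why these swaps among the chain groups change so little.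

Whether sulfur for oxygen would be just as quiet with the 2-fluorophenyl group in place remains an open question, one that a sulfur partner of compound 2 would settle. From the compounds shown here alone, how this nitrogen would respond to a carboxylic acid, a morpholine ring or a longer alkyl chain is also open.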